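Constrained cyclic amine replaces methyl(phenyl)amino on the core

A few compounds are considered here, and "the series" means these few. Any claim that something is new, unique, unknown or untested is made for them only; others in the source may bear on it.

The series is read in an assay on HEK293 cells for inhibition of Fatty-acid amide hydrolase 1 (Homo sapiens), read by fluorescence; a higher number here means a weaker inhibitor, a lower number a stronger inhibitor. Compound 1 `c1cnc2ccc(-c3ccc4oc(NC5CCCCC5)nc4c3)cc2c1` reports only a limit of > 1000 nM in this assay. Within the data shown here, compound 2 `CN(c1ccccc1)c1nc2cc(-c3ccc4c(ccn4C)c3)ccc2o1` gives 68 nM in this assay, and compound 3 `Cn1ccc2cc(-c3ccc4oc(N5CCN(c6ccccc6)CC5)nc4c3)ccc21` gives 63 nM; these are the only two numbers known, and they sit within the scatter of each other, so neither is placed above the other. Compound 4 `Cn1ccc2cc(-c3ccc4oc(N5CCn6cccc6C5)nc4c3)ccc21` is not yet measured. It differs from compound 2 by a group of 9 heavy atoms (7 carbon, 2 nitrogen; one five-membered aromatic ring with 1 hetero atom, one six-membered non-aromatic ring with 2 hetero atoms) in place of a group of 8 heavy atoms (7 carbon, 1 nitrogen; one six-membered aromatic ring of carbon only), on an aromatic carbon. No measured step of this kind exists among the compounds shown; compound 3 also carries an amine bound into a ring and its value agrees with that of compound 2, so a change in this assay of about the scatter is expected, leaning slightly toward a weaker inhibitor. Compound 4 is expected to give 120 nM in this assay, with a range of 40 nM to 400 nM. The expected step is a 1.8-fold higher number from compound 2 to compound 4 (0.25 log units; within the scatter).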

Compound 4, half-maximal inhibitory concentration: 42 nM
Estimate against measurement, compound 4: 2.9-fold (0.46 log units) above; the measured number falls inside the stated range.
By their numbers in this assay, from the lowest: compounds 4, 3 and 2 (each within the scatter of the next). At a limit, above all of these: compound 1.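

The step from methyl(phenyl)amino to the group carrying a five-membered aromatic ring and a six-membered non-aromatic ring, on an aromatic carbon of a five-membered aromatic ring with 1 nitrogen and 1 oxygen, stays within the scatter in this assay: a 1.6-fold lower number from compound 2 to compound 4 (0.21 log units; within the scatter). This position therefore accepts a group with no phenyl ring and no methyl group without a loss beyond the scatter. Nothing shown gives a cause for this step.

Still open, from the compounds shown here alone, is how a small open-chain amine such as dimethylamino would read at this position. Also open, going by these compounds, is the effect of a carboxylic acid on the new ring.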